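The source may hold more compounds than are shown below. What is called first, only, known or untested is meant among the compounds shown, and "the series" means these compounds.

Measured so far:
compound 1, `S=C(N/N=C/c1ccc2ccccc2n1)Nc1cccc(Cl)c1`: 28800 nM
compound 2, `CN(C)C(=S)N/N=C/c1cnc2ccccc2n1`: 90 nM

In a functional assay on HL-60 cells (Homo sapiens) for antiproliferative activity, read by sulforhodamine B assay, with a stated time of 72 h (on this read-out lower numbers stand for stronger inhibition and higher numbers for weaker inhibition), compound 1 gives 28800 nM, the highest of the two numbers. Compound 2 gives 90 nM, a gap well beyond the scatter. Compound 3, `S=C(N/N=C/c1ccc2ccccc2n1)Nc1ccc(Cl)cc1`, differs from compound 1 only in this: 4-chlorophenyl in place of 3-chlorophenyl on an amide-type nitrogen. Among the compounds with values here, no measured pair shows what this change does, so the step of a 1.2-fold lower number from compound 1 to compound 3 (0.06 log units; within the scatter) is expected to be small, with no direction beyond the scatter. Compound 3 is therefore estimated at 25000 nM, with a range from 8000 nM to 80000 nM.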

Compound 3, half-maximal inhibitory concentration: > 100000 nM
Compound 3 was reported as a limit; the forecaster's own chance of this, stated with the estimate: 15%; middle value at least 4.0-fold (0.60 log units) from the limit.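

In this assay, compound 3 is reported only as a limit, > 100000 nM. Setting 4-chlorophenyl in place of 3-chlorophenyl on an amide-type nitrogen gives an at least 3.4-fold higher number from compound 1 to compound 3 (0.54 log units; beyond the scatter), so the number at this position depends on where the chlorine sits, though the two compounds have the same atoms. The size of this step is known only up to a bound: the limit of > 100000 nM in this assay, at which 1 of the 3 values shown sits.

On these data alone, how far compound 3 lies past its limit remains open. So does the effect of an unsubstituted phenyl, a methoxyphenyl or a small alkyl group such as methyl on this nitrogen.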